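Replacing 5-chloro-1-benzothiophen-3-yl with cyclohexyl: working notes

The compounds below may be only part of what the source reports. "The series", "measured", "known", "first", "only" and "open" are said of these compounds alone.

In a functional assay on MGC-803 cells (Homo sapiens) for inhibition, read by MTT assay, with a stated time of 72 h (on this read-out lower numbers stand for stronger inhibition and higher numbers for weaker inhibition), compound 3 `Cc1cc(N2CC[C@@H](C)[C@@H](N(C)c3ncnc4[nH]ccc34)C2)n2nc(SCc3csc4ccc(Cl)cc34)nc2n1` gives > 100000 nM, which is a limit and not a number: the limit of > 100000 nM in this assay, at which 1 of the 3 values shown sits. Compound 1 `Cc1cc(N2CC[C@@H](C)[C@@H](N(C)c3ncnc4[nH]ccc34)C2)n2nc(SCc3ccc(Cl)cc3)nc2n1` gives 16000 nM and compound 2 `Cc1cc(N2CC[C@@H](C)[C@@H](N(C)c3ncnc4[nH]ccc34)C2)n2nc(SCC3CC3)nc2n1` gives 9540 nM. The step between these two is a 1.7-fold lower number from compound 1 to compound 2 (0.22 log units; within the scatter), so 4-chlorophenyl and cyclopropyl on the saturated chain carbon bound to a sulfur are not told apart in this assay.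

Compound 4 `Cc1cc(N2CC[C@@H](C)[C@@H](N(C)c3ncnc4[nH]ccc34)C2)n2nc(SCC3CCCCC3)nc2n1` carries cyclohexyl in place of 5-chloro-1-benzothiophen-3-yl on a saturated chain carbon bound to a sulfur.

Two measured steps leave 5-chloro-1-benzothiophen-3-yl as the entering group. They are an at least 6.2-fold higher number from compound 1 to compound 3 (0.79 log units; beyond the scatter) and an at least 10-fold higher number from compound 2 to compound 3 (1.02 log units; beyond the scatter). Both are beyond the scatter, and both have only a minimum size. The second is the closer guide, since it starts from a non-aromatic ring in compound 2. Among the compounds with values here, the change to compound 4 runs the opposite way, so a drop of similar size is the working expectation, though no cyclohexyl compound has been measured yet. The expected step is an at least 7.6-fold lower number from compound 3 to compound 4 (0.88 log units; beyond the scatter), towards a lower number and of uncertain exact size. The estimate for compound 4 is 13000 nM, with an expected range of 5000 nM to 40000 nM.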

Compound 4, half-maximal inhibitory concentration: 9170 nM
Beside the measured number, compound 4's estimate is 1.4-fold (0.15 log units) above it, and the stated range covers the measured number.
By their numbers in this assay, from the lowest: compounds 4, 2 and 1 (each within the scatter of the next). At a limit, above all of these: compound 3.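

With cyclohexyl the series returns from the limit to a measurable number in this assay: an at least 10-fold lower number from compound 3 to compound 4 (1.03 log units; beyond the scatter). Together with a 1.0-fold lower number from compound 2 to compound 4 (0.02 log units; within the scatter) and a 1.7-fold lower number from compound 1 to compound 4 (0.24 log units; within the scatter), this shows that cyclopropyl, cyclohexyl and 4-chlorophenyl on a saturated chain carbon bound to a sulfur are not told apart in this assay, so neither the step up from the small ring to the six-membered non-aromatic ring nor the swap of that ring for an aromatic one registers here. Of the four groups now shown at this place, 5-chloro-1-benzothiophen-3-yl alone stands apart, and compound 3 is held at a limit and not a number, so the true size of its steps stays unknown: the limit of > 100000 nM in this assay, at which 1 of the 4 values shown sits.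

Open, going by these compounds, is whether any group at this place moves the number below the level shared by compounds 1, 2 and 4, for instance an amine, a carboxylic acid or a longer chain in place of cyclohexylmethyl. Also open, on these data alone, is which part of 5-chloro-1-benzothiophen-3-yl goes with the loss in compound 3, a question that a 1-benzothiophen-3-yl without the chlorine would address.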